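From Fluoro to Methyl on an Aromatic Carbon

The compounds below may be only part of what the source reports. "The series", "measured", "known", "first", "only" and "open" are said of these compounds alone.

Sharing one core, compound 1 (`COc1ccccc1NC(=O)Nc1cccc(CNc2nccnc2Cl)c1`) gives 13700 nM in a functional assay on HepG2 cells (Homo sapiens) for antiproliferative activity, read by MTT assay, with a stated time of 48 h (on this read-out higher numbers stand for weaker inhibition and lower numbers for stronger inhibition), and compound 2 (`O=C(Nc1cccc(CNc2nccnc2Cl)c1)Nc1ccc(Cl)cc1Cl`) gives 7230 nM there. Compound 3 (`O=C(Nc1cccc(CNc2nccnc2Cl)c1)Nc1ccccc1F`) gives 10500 nM and has no clear rank, as its number cannot be separated from either of the others.

Compound 4 (`Cc1ccccc1NC(=O)Nc1cccc(CNc2nccnc2Cl)c1`), not yet measured, carries methyl in place of fluoro on an aromatic carbon, ortho to a large group (methyl in place of fluoro on an aromatic carbon). For the measured compounds named here, no measured step makes this exact swap, so the nearest guides are related changes. Fluoro in place of methoxy gave a 1.3-fold lower number from compound 1 to compound 3 (0.12 log units; within the scatter) and 2-fluorophenyl in place of 2,4-dichlorophenyl gave a 1.5-fold higher number from compound 2 to compound 3 (0.16 log units; within the scatter) while 2,4-dichlorophenyl in place of 2-methoxyphenyl gave a 1.9-fold lower number from compound 1 to compound 2 (0.28 log units; within the scatter) in this small set. With steps this small, no step beyond the scatter is expected in this assay from the new swap. The estimate is therefore a 1.1-fold lower number from compound 3 to compound 4 (0.02 log units; within the scatter) as the expected step. For compound 4 the estimated value is 10000 nM with a range from 5500 nM to 18000 nM overall.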

Compound 4, half-maximal inhibitory concentration: 15300 nM
Compound 4: middle estimate off by 1.5-fold (0.18 log units), on the low side, within the range that was stated.
By their numbers in this assay, from the lowest: compounds 2, 3, 1 and 4 (each within the scatter of the next, the first and the last beyond it).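

In this assay, methyl in place of fluoro, ortho to a large group, gives a 1.5-fold higher number from compound 3 to compound 4 (0.16 log units; within the scatter), and methyl in place of methoxy gives a 1.1-fold higher number from compound 1 to compound 4 (0.05 log units; within the scatter), so the 2-fluorophenyl, 2-methoxyphenyl and 2-methylphenyl versions cannot be told apart. For the compounds shown here, compound 4 also supplies the first step in this set that clears the scatter: 2-methylphenyl in place of 2,4-dichlorophenyl gives a 2.1-fold higher number from compound 2 to compound 4 (0.33 log units; beyond the scatter), a modest step that still rests on a single pair. Nothing measured here bears on why the numbers fall this way.

Open, from the compounds shown here alone, is how an amine or a carboxylic acid would read at this same place on the shared core. Also open, going by these compounds, is whether a single chloro would match the number of compound 2, or whether that step needs both chlorines of 2,4-dichlorophenyl.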